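A few compounds are considered here, and "the series" means these few. Any claim that something is new, unique, unknown or untested is made for them only; others in the source may bear on it.

Working notes on the series

Compound 1 `N#Cc1c(Nc2ccc(Cl)cc2)nc(SCC(=O)Nn2c(COc3ccc(Cl)cc3Cl)nc3ccccc3c2=O)nc1-c1ccc(Cl)cc1` gives 54.6% in a functional assay on the whole organism (strain albino) for inhibition, with Rattus norvegicus as the target, read by paw edema, with a stated time of 1 h, at a dose of 100 mg/kg by the oral route; on this read-out lower numbers stand for less inhibition and higher numbers for more inhibition at the one dose given (going by the name of the read-out). Compound 2 `N#Cc1c(Nc2ccc(O)cc2)nc(SCC(=O)Nn2c(COc3ccc(Cl)cc3Cl)nc3ccccc3c2=O)nc1-c1ccc(Cl)cc1` gives 90.9% in this assay. Among the measured compounds shown here, the one change between them, hydroxy in place of chloro on an aromatic carbon, gives a number 36.3 percentage points higher from compound 1 to compound 2 (beyond the scatter). For the measured compounds named here, compound 2 therefore stands highest of the two numbers measured so far, with compound 1 the nearest and well beyond the scatter below it.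

Compound 3 `N#Cc1c(Nc2ccc(O)cc2)nc(SCC(=O)Nn2c(COc3ccc(Cl)cc3Cl)nc3ccccc3c2=O)nc1-c1ccc(O)cc1` is not yet measured in this assay. It differs from compound 2 as hydroxy in place of chloro on an aromatic carbon. The same kind of exchange has been seen once, in the step of a number 36.3 percentage points higher from compound 1 to compound 2 (beyond the scatter), though there it sat on the other aromatic ring of the shared core, so it bears on the new step only loosely. On that basis the step is expected to be upward or flat rather than downward, but compound 2 already reads near the top of the scale, which leaves little room; the expected step is a number 2.9 percentage points lower from compound 2 to compound 3 (within the scatter), likely within the scatter.

Compound 3 is estimated at 88% in this assay, with a range of 72% to 98%.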

Compound 3, a percentage reported as inhibition, in the whole organism at one dose (the size of the read-out at that dose, not a potency): 86.4%
Estimate against measurement, compound 3: 1.6 percentage points above; the range from low to high includes it.
By their numbers in this assay, from the lowest: compound 1; then compounds 3 and 2 (each within the scatter of the next).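

The exchange of 4-chlorophenyl to 4-hydroxyphenyl gives a number 4.5 percentage points lower from compound 2 to compound 3 (within the scatter) in this assay, so at this position it does not repeat the large step of a number 36.3 percentage points higher from compound 1 to compound 2 (beyond the scatter), which came from the same exchange of chloro for hydroxy on the other aromatic ring. Across these two steps, the size of the effect therefore differs with the place of the exchange, although compound 2 at 90.9% already stands high on the scale and leaves little room for a rise, so this single comparison cannot show how far the position itself matters. Nothing at hand accounts for the difference between the two steps.

Still open is how hydroxy on this ring reads when chloro stays on the other aromatic ring, since both steps shown start from different partners and only that pairing would separate the two places cleanly. Also open, going by these compounds, is whether a group other than chloro or hydroxy at this position, such as an amine, a methoxy or a carboxylic acid, holds the reading at this level or moves it beyond the scatter.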